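Ethoxycarbonyl in place of cyano, starting from a limit

A few compounds are considered here, and "the series" means these few. Any claim that something is new, unique, unknown or untested is made for them only; others in the source may bear on it.

Compound 3 (`CCN(CC)c1ccc(-c2cccc(C#N)c2)nn1`) is the starting point, and its activity was read in an ADME assay on HaCaT cells (Homo sapiens) for antiproliferative activity, with a stated time of 48 h; a lower number here means a stronger inhibitor, a higher number a weaker inhibitor. In this assay compound 3 gives > 25000 nM, which is a limit and not a number. Two close relatives share its core: compound 1 (`CCN(CC)c1ccc(-c2cccc(Cl)c2)nn1`) and compound 2 (`CCN(CC)c1ccc(-c2cccc(C(F)(F)F)c2)nn1`). Compound 1 gives > 25000 nM, which is also a limit. Compound 2 gives > 25000 nM, again a limit. All three measurements therefore stand together at the limit of > 25000 nM in this assay, at which 3 of the 3 values shown sit.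

The next compound, compound 4 (`CCOC(=O)c1cccc(-c2ccc(N(CC)CC)nn2)c1`), carries ethoxycarbonyl in place of cyano on an aromatic carbon.

Three measured steps exchange one group on an aromatic carbon for another, so they are the nearest guides. Trifluoromethyl in place of chloro is a step that the two limits leave unreadable from compound 1 to compound 2. Cyano in place of chloro is a step that the two limits leave unreadable from compound 1 to compound 3. Cyano in place of trifluoromethyl is a step that the two limits leave unreadable from compound 2 to compound 3. None of the three gives a size to carry over, so no shift in either direction is expected beyond the scatter, and another limit is the likeliest report. The expected change is a step that the limit leaves unreadable from compound 3 to compound 4. Compound 4 is estimated at 30000 nM, with an expected range from 15000 nM to 60000 nM.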

Compound 4, half-maximal inhibitory concentration: > 25000 nM
Compound 4 gave a limit, no number; the forecaster's own chance of this, stated with the estimate: 85%; the middle value lies beyond the limit too.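

In this assay compound 4 gives only a limit, as do compound 1, compound 2 and compound 3, so no step among these compounds can be read, and all four stand together: the limit of > 25000 nM in this assay, at which 4 of the 4 values shown sit.

The compounds shown leave open whether any group at this place on the shared core gives a measurable value, and how far chloro, trifluoromethyl, cyano and ethoxycarbonyl differ.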